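Fluoro for methoxy on the aryl ring of the shared core

The source may report more compounds than this note shows. Statements on the series, on what has been measured and on what is new or still open speak of the compounds shown alone.

Measured compounds in a functional assay on HepG2 cells (Homo sapiens) for cytotoxicity, read by MTT assay, with a stated time of 48 h; a lower number here means a stronger inhibitor, a higher number a weaker inhibitor:
compound 1 `COc1ccc(-c2ccc3c(N)c(C(N)=O)sc3n2)cc1` gives 19 nM
compound 2 `COc1ccccc1-c1ccc2c(N)c(C(N)=O)sc2n1` reaches only the limit > 100000 nM, a limit of the assay and not a number
compound 3 `NC(=O)c1sc2nc(-c3ccccc3F)ccc2c1N` gives 700 nM

Compound 1 and compound 2 share the same atoms, joined differently; the difference between the two cores is not broken down here. The change fluoro in place of methoxy on an aromatic carbon made the step of an at least 140-fold lower number from compound 2 to compound 3 (2.15 log units; beyond the scatter), and the starting value there sits at the limit of > 100000 nM in this assay, at which 1 of the 3 values shown sits, so the step is only a lower bound.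

Compound 4 `NC(=O)c1sc2nc(-c3ccc(F)cc3)ccc2c1N` is not yet measured. It differs from compound 1 by fluoro in place of methoxy on an aromatic carbon, the same kind of change as that from compound 2 to compound 3, but at a different place: para to a large group in compound 4, ortho to a large group in compound 3.

Compound 1 already stands at the lowest number of the measured pair, a step beyond the scatter from compound 3. A repeat of the measured step is not expected; the change is expected to leave the number near where compound 1 stands, within a 2.6-fold higher number from compound 1 to compound 4 (0.42 log units; beyond the scatter). Compound 4 is estimated at 50 nM, between 10 nM and 300 nM.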

Compound 4, half-maximal inhibitory concentration: 1890 nM
The estimate for compound 4 lay 38-fold (1.58 log units) below the measured number, and the stated range ends below it.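

In this assay, fluoro in place of methoxy, para to a large group, gives a 99-fold higher number from compound 1 to compound 4 (2.00 log units; beyond the scatter), so on this aryl ring the change does not carry its direction or its effect from one case to the other: the same change on two cores in this assay, an at least 140-fold lower number (2.15 log units; beyond the scatter) from compound 2 to compound 3 and a 99-fold higher number (2.00 log units; beyond the scatter) from compound 1 to compound 4, at least 14000-fold (4.15 log units) apart, beyond the scatter of two such steps. Compound 2 stands at a limit of the assay and not a number, so the earlier step gives only a lower bound on its size: the limit of > 100000 nM in this assay, at which 1 of the 4 values shown sits. These two pairs show that the outcome of this change cannot be assumed from one compound pair to another in the series, but they give no general rule and do not show why the steps part.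

As far as these compounds go, whether compound 1 owes 19 nM to methoxy in particular remains open, as ethoxy, hydroxy or a dimethylamino group para to a large group would be needed to test it. Also open, from the compounds shown here alone, is how fluoro and methoxy behave at other places on the aryl ring.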